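From a Bare Triple Bond to 4-Fluorophenyl

The compounds below may be only part of what the source reports. "The series", "measured", "known", "first", "only" and "open" are said of these compounds alone.

In a functional assay on PC-3 cells (Homo sapiens) for antiproliferative activity, read by WST assay, with a stated time of 72 h (a higher number here means a weaker inhibitor of growth, a lower number a stronger inhibitor of growth), compound 2 `C#Cc1ccccc1N/N=N/c1ccc(C(=N)N)cc1` reads > 50000 nM, which is a limit of the assay and not a number. Compound 1 `N=C(N)c1ccc(/N=N/Nc2ccccc2C#Cc2ccccc2)cc1` gives 5300 nM in this assay. Compound 3 `N=C(N)c1ccc(/N=N/Nc2ccccc2C#Cc2ccc(F)cc2)cc1` changes compound 2 by placing 4-fluorophenyl in place of hydrogen on a triple-bonded carbon. Among the compounds with values here, the one measured step bearing on this is the loss of phenyl at that carbon, which gave an at least 9.4-fold higher number from compound 1 to compound 2 (0.97 log units; beyond the scatter), beyond the scatter. A step in the opposite direction, towards stronger growth inhibition and of similar size, is therefore expected, namely an at least 10-fold lower number from compound 2 to compound 3 (1.00 log units; beyond the scatter). The estimate for compound 3 is 5000 nM, within a range of 1700 nM to 15000 nM.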

Compound 3, concentration for 50% growth inhibition: 7400 nM
Estimate against measurement, compound 3: 1.5-fold (0.17 log units) below, and the stated range covers the measured number.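

Placing 4-fluorophenyl on the triple-bonded carbon gives an at least 6.7-fold lower number from compound 2 to compound 3 (0.82 log units; beyond the scatter) in this assay, so a second substituted ring, not only phenyl, goes with stronger growth inhibition than hydrogen at this carbon. The size of that step is only a bound, and compound 2 stands at a limit of the assay, not at a number: the limit of > 50000 nM in this assay, at which 1 of the 3 values shown sits. Fluoro in place of hydrogen on an aromatic carbon gives a 1.4-fold higher number from compound 1 to compound 3 (0.14 log units; within the scatter) and so cannot be told apart from phenyl alone here. As far as these compounds go, whether an amine or a carboxylic acid on that ring would shift the number remains open, as does the effect of a longer chain in place of the ring.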